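Amine side-chain swap on the cytotoxicity read-out

A few compounds are considered here, and "the series" means these few. Any claim that something is new, unique, unknown or untested is made for them only; others in the source may bear on it.

Compound 1 `Cc1ccc2nc(N3CCCc4ccc(F)cc4C3)cc(NCC3(N)COC3)c2c1` sits at the top of the range seen so far in an ADME assay on HEp-2 cells (Homo sapiens) for cytotoxicity, read by CCK-8 assay, with a stated time of 5 days; on this read-out higher numbers stand for lower toxicity in this test and lower numbers for higher toxicity in this test. In this assay compound 1 gives > 100000 nM, which is a limit of the assay and not a number. The other two members of the series are compound 2 `NCC(O)CNc1cc(N2CCCc3ccccc3C2)nc2ccccc12`, which in this assay gives 21000 nM, and compound 3 `NCCNc1cc(N2CCCc3ccccc3C2)nc2c(Cl)cccc12`, which in this assay gives 25000 nM; those two values lie within the scatter of each other. Compound 1 stands apart from them only as the limit, as noted in the limit of > 100000 nM in this assay, at which 1 of the 3 values shown sits.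

Compound 4 `Cc1ccc2nc(N3CCCc4ccc(F)cc4C3)cc(NC(=O)CN)c2c1` differs from compound 1 in one place: (aminomethyl)carbonyl in place of (3-aminooxetan-3-yl)methyl on a nitrogen on an aromatic ring. Among the measured compounds shown here, no pair of measured compounds shows what this change does to the cytotoxicity read-out, so the direction is open. The step from compound 1 to compound 4 is expected to be small, no larger than the scatter, with the estimated change an at least 1.4-fold lower number from compound 1 to compound 4 (0.15 log units; that floor lies within the scatter) resting on the limit of compound 1 > 100000 nM. Compound 4 is estimated at 70000 nM, with a range from 25000 nM to 150000 nM, and a fair chance that only a limit is again reported.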

Compound 4, half-maximal cytotoxic concentration: > 100000 nM
Compound 4 was reported as a limit; the forecaster's own chance of this, stated with the estimate: 45%; middle value at least 1.4-fold (0.15 log units) from the limit.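

Among the compounds shown here, compound 1 and compound 4 both stand only as limits in this assay, so no step between them can be read: the limit of > 100000 nM in this assay, at which 2 of the 4 values shown sit. The compounds shown leave open whether (aminomethyl)carbonyl and (3-aminooxetan-3-yl)methyl differ at all on this read-out.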